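Cyclohexyl to fluoro: what compound 4 should give

The source may report more compounds than this note shows. Statements on the series, on what has been measured and on what is new or still open speak of the compounds shown alone.

Compound 1 `O=C1NCCN1c1ccc(S(=O)(=O)Nc2ccc(C3CCCCC3)cc2)cc1` carries a cyclohexyl group on the shared core. In a functional assay on M21 cells (Homo sapiens) for antiproliferative activity, read by sulforhodamine B assay, with a stated time of 48 h (on this read-out higher numbers stand for weaker inhibition and lower numbers for stronger inhibition), compound 1 reports only a limit, > 1000 nM, and no number. Compound 1 thus sits at the limit of > 1000 nM in this assay, at which 1 of the 3 values shown sits. Compound 2 `O=C1NCCN1c1ccc(S(=O)(=O)Nc2ccc(Br)cc2)cc1`, bromo in place of cyclohexyl, gives 130 nM in this assay, and compound 3 `O=C1NCCN1c1ccc(S(=O)(=O)Nc2ccc3[nH]ccc3c2)cc1` gives 87 nM; those two lie within the scatter of each other. The change to compound 4 `O=C1NCCN1c1ccc(S(=O)(=O)Nc2ccc(F)cc2)cc1` is fluoro in place of cyclohexyl on an aromatic carbon. For the measured compounds named here, the one measured step that bears on it is an at least 7.6-fold lower number from compound 1 to compound 2 (0.88 log units; beyond the scatter), where another single heavy atom replaced the same cyclohexyl. Going by these compounds, since the exchange of cyclohexyl for a single heavy atom gave an at least 7.6-fold lower number from compound 1 to compound 2 (0.88 log units; beyond the scatter), a step of at least modest size in the same direction, towards a lower number, is expected for compound 4 as well, though bromo and fluoro need not read alike and the fluoro case is untested here. Compound 4 is expected to give about 250 nM in this assay, within 70 nM to 900 nM. The step this estimate implies is an at least 4.0-fold lower number from compound 1 to compound 4 (0.60 log units; beyond the scatter).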

Compound 4, half-maximal inhibitory concentration: 230 nM
Estimate against measurement, compound 4: 1.1-fold (0.04 log units) above; low and high end bracket the measured number.
By their numbers in this assay, from the lowest: compounds 3, 2 and 4 (each within the scatter of the next, the first and the last beyond it). At a limit, above all of these: compound 1.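

In this assay the exchange of cyclohexyl for a single heavy atom on this aromatic carbon now has a second case, with fluoro, so the change no longer rests on bromo alone: an at least 4.3-fold lower number from compound 1 to compound 4 (0.63 log units; beyond the scatter). The choice of halogen makes no readable difference at this position, with a 1.8-fold higher number from compound 2 to compound 4 (0.25 log units; within the scatter). Compound 1 remains a limit and not a number, so the size of the step from it is only a bound: the limit of > 1000 nM in this assay, at which 1 of the 4 values shown sits.

Open, going by these compounds, is how a group of intermediate size, such as methyl, ethyl or a longer chain, would read at this position, and at what size the number reaches the limit. Also open are an amine and a carboxylic acid here; fluoro and cyclohexyl both count no hydrogen-bond donors or acceptors, so the compounds shown say nothing about such groups.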